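Methoxy for Trifluoromethyl on a Shared Core

A few compounds are considered here, and "the series" means these few. Any claim that something is new, unique, unknown or untested is made for them only; others in the source may bear on it.

Compound 1 `O=C(NCc1ccccc1C(F)(F)F)N1C(=O)c2ccccc2S1(=O)=O` was examined in a physicochemical assay for pharmacokinetics; on this read-out higher numbers stand for a longer-lived compound and lower numbers for a shorter-lived compound. In this assay compound 1 reaches > 166 h, which is a limit of the assay rather than a number. Compound 2 `O=C(NCc1cccc2ccccc12)N1C(=O)c2ccccc2S1(=O)=O` shares the core of compound 1 and carries a different side group. In this assay compound 2 likewise reaches > 166 h, again a limit and not a number. Within the data shown here, compound 1 thus stands at the limit of > 166 h in this assay, at which 2 of the 2 values shown sit, and no step between measured compounds can be read from the two values. Compound 3 `COc1ccccc1CNC(=O)N1C(=O)c2ccccc2S1(=O)=O` differs from compound 1 in one place (methoxy in place of trifluoromethyl on an aromatic carbon). With both measured compounds at the limit, no direction is indicated, and the step in this assay is expected to be small, a number no higher from compound 1 to compound 3 (the limit leaves the size open), within the usual scatter. Compound 3 is therefore expected to give about 166 h in this assay, within a range from 60 h to 500 h, most likely reported once more as a limit.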

Compound 3, half-life: > 166 h
Compound 3: a limit, no number; the forecaster's own chance of this, stated with the estimate: 70%; the middle value lies on the limit itself.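

In this assay compound 3 gives > 166 h, a limit and not a number. No step from compound 1 to compound 3 can be read: the limit of > 166 h in this assay, at which 3 of the 3 values shown sit.

The compounds shown leave open the actual half-life of each, and so whether methoxy in place of trifluoromethyl changes it at all.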